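The source may report more compounds than this note shows. Statements on the series, on what has been measured and on what is new or still open speak of the compounds shown alone.

Series notes. Compound 1 `CCCCc1cnc(C(C)Cc2ccc(-c3ccccc3C(=O)O)cc2)[nH]1` gives 184 nM in an in vitro functional assay on cells for agonist activity at Bombesin receptor subtype-3 (Mus musculus), read by luminescence and calcium flux; a lower number here means that less compound is needed, a higher number that more compound is needed for the effect. Compound 2 `CCCCc1cnc(C(CCC)Cc2ccc(-c3ccccc3C(=O)O)cc2)[nH]1` gives 165 nM in this assay, so that the step of a 1.1-fold lower number from compound 1 to compound 2 (0.05 log units; within the scatter) stays within the scatter. Compound 3 `Cc1cccc(Cc2cnc(CCc3ccc(-c4ccccc4C(=O)O)cc3)[nH]2)c1` gives 75 nM in this assay, the lowest of the three numbers, standing beyond the scatter from both compound 2 and compound 1.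

Compound 4 `N#Cc1ccccc1Cc1cnc(CCc2ccc(-c3ccccc3C(=O)O)cc2)[nH]1` has not been measured. It differs from compound 3 in one place: 2-cyanophenyl in place of 3-methylphenyl on a saturated chain carbon bound to an aromatic carbon. Among the compounds with values here, the only measured step in the set concerns the chain and not the 3-methylphenyl group, and it was within the scatter; no measured pair exchanges one substituted phenyl for another. Nothing here bears directly on the change at hand, so no step beyond the scatter is expected in this assay in either direction, while the range is kept wide for want of a comparison. Compound 4 is expected to give 110 nM with a range of 35 nM to 350 nM. The estimated step of a 1.5-fold higher number from compound 3 to compound 4 (0.17 log units; within the scatter) is expected to lie within the scatter.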

Compound 4, half-maximal effective concentration: 642 nM
Estimate against measurement, compound 4: 5.8-fold (0.77 log units) below; the measured number lies above the stated range.
By their numbers in this assay, from the lowest: compound 3; then compounds 2 and 1 (each within the scatter of the next); then compound 4.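

The group on the saturated chain carbon bound to an aromatic carbon turns out to matter in this assay: 2-cyanophenyl in place of 3-methylphenyl gives an 8.6-fold higher number from compound 3 to compound 4 (0.93 log units; beyond the scatter). Within the data shown here, the only earlier step, a 1.1-fold lower number from compound 1 to compound 2 (0.05 log units; within the scatter), concerned the chain on the other side of the ring bearing this group and showed no change beyond the scatter, so this is the first sign that the number responds to a structural change, and the response is towards needing more compound. No measurement in hand accounts for the size of this step.

The exchange alters both the substituent and its printed ring position at once, leaving open whether the nitrile or its placement drives the step. 3-Cyanophenyl and 2-methylphenyl at this carbon would separate the two, and unsubstituted phenyl would show how far the 3-methyl group itself contributes to the number of compound 3.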